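Amine side chain extension from compound 3 to compound 4

A few compounds are considered here, and "the series" means these few. Any claim that something is new, unique, unknown or untested is made for them only; others in the source may bear on it.

Values in a toxicity assay on L6 cells (Rattus norvegicus) for inhibition, read by microscopy and resazurin assay, with a stated time of 70 h; a lower number here means a stronger inhibitor, a higher number a weaker inhibitor:
- compound 1 `CC1(C)CCc2c(ccc(CNCc3ccccc3)c2O)O1` gives 60000 nM
- compound 2 `CC1(C)CCc2cc(CNCc3ccccc3)c(O)cc2O1` gives 22000 nM
- compound 3 `CC1(C)CCc2cc(CNCCCc3ccccc3)c(O)cc2O1` gives 6500 nM
- compound 4 `CC1(C)CCc2cc(CNCCCCc3ccccc3)c(O)cc2O1` is not yet measured

Compound 3 holds the lowest number of the three, with compound 2 nearest and compound 1 furthest. The next change, to compound 4, is benzyl in place of phenyl on a saturated chain carbon, three bonds along the chain from an amine nitrogen.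

Going by the values given here, the only measured step bearing on this is a 3.4-fold lower number from compound 2 to compound 3 (0.53 log units; beyond the scatter), a modest change beyond the scatter that also extends the chain on the amine nitrogen. Among the compounds with values here, compound 1 is joined to the others by no single-place step and offers no guide. One step does not establish a trend, but a further lowering of similar or smaller size is expected in this assay. The expected step is a 1.9-fold lower number from compound 3 to compound 4 (0.27 log units; within the scatter). For compound 4 the estimated value is 3500 nM, with an expected range of 1500 nM to 8000 nM.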

Compound 4, half-maximal inhibitory concentration: 15000 nM
The estimate for compound 4 lay 4.3-fold (0.63 log units) below the measured number; measured number above the stated range.
By their numbers in this assay, from the lowest: compound 3; then compounds 4 and 2 (each within the scatter of the next); then compound 1.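

In this assay, benzyl in place of phenyl on a saturated chain carbon, three bonds along the chain from an amine nitrogen, gives a 2.3-fold higher number from compound 3 to compound 4 (0.36 log units; beyond the scatter) and so reverses the direction of a 3.4-fold lower number from compound 2 to compound 3 (0.53 log units; beyond the scatter) within this short run of chains. Compound 4 at 15000 nM and compound 2 at 22000 nM stand within the scatter of each other, so the number does not follow chain length in one direction, and compound 3 is the low point of the run. Nothing measured here accounts for the reversal.

From the compounds shown here alone, whether a longer chain would raise the number further, or lower it again, remains open. Also open, going by these compounds, is how a pyridine in place of the terminal phenyl, or a methoxy group on it, would behave at the chain length of compound 3.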